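Dropping the Fluoro Group on the Sulfonyl-Side Ring

The source may report more compounds than this note shows. Statements on the series, on what has been measured and on what is new or still open speak of the compounds shown alone.

Measured compounds:
- compound 1, `O=C(Cc1ccc(F)cc1)NS(=O)(=O)c1ccc(Cl)cc1`, 6.28 ug/mL
- compound 2, `O=C(Cc1ccc(F)cc1)NS(=O)(=O)c1ccc(F)cc1`, 5.64 ug/mL
- compound 3, `Cc1ncc([N+](=O)[O-])n1CC(=O)NS(=O)(=O)c1ccccc1`, 3.96 ug/mL

All three were tested in a functional assay on A549 cells (Homo sapiens) for antiproliferative activity, read by MTT assay, with a stated time of 48 h; on this read-out higher numbers stand for weaker inhibition and lower numbers for stronger inhibition. Among these numbers compound 2 stands second highest, with compound 1 nearest and compound 3 furthest, and both gaps lie within the scatter. Within the data shown here, the one step between compounds that differ in a single place, a 1.1-fold lower number from compound 1 to compound 2 (0.05 log units; within the scatter), also lies within the scatter. Compound 4, `O=C(Cc1ccc(F)cc1)NS(=O)(=O)c1ccccc1`, carries this series one stage further: hydrogen in place of fluoro on an aromatic carbon. Since the halogen swap at that same aromatic carbon changed little, no step beyond the scatter is expected here either. Compound 4 is therefore estimated at 6 ug/mL, with a range from 3 ug/mL to 12 ug/mL, an expected step of a 1.1-fold higher number from compound 2 to compound 4 (0.03 log units; within the scatter).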

Compound 4, half-maximal inhibitory concentration: 10.1 ug/mL
For compound 4 the middle estimate is 1.7-fold (0.23 log units) below the measured one; the range from low to high includes it.
By their numbers in this assay, from the lowest: compounds 3, 2, 1 and 4 (each within the scatter of the next, the first and the last beyond it).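

In this assay, removing the halogen from this aromatic carbon altogether gives a 1.8-fold higher number from compound 2 to compound 4 (0.25 log units; within the scatter), and starting from the chloro compound gives a 1.6-fold higher number from compound 1 to compound 4 (0.21 log units; within the scatter). Both steps stay within the scatter, so among these compounds hydrogen, fluoro and chloro at this carbon cannot be told apart, and the halogen is not needed to keep the number in this range. Nothing measured here offers an explanation for these numbers. Going by these compounds, whether an amine, a carboxylic acid or a longer chain at this carbon would produce a step beyond the scatter remains open.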